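The source may hold more compounds than are shown below. What is called first, only, known or untested is meant among the compounds shown, and "the series" means these compounds.

Compound 1, `CCc1cc(-c2nn(C(C)C)c3ncnc(N)c23)no1`, carries ethyl on its five-membered ring and isopropyl on the aromatic nitrogen of the shared core. In an assay on BaF3 cells for inhibition of proto-oncogene tyrosine-protein kinase receptor Ret variant V804M (Homo sapiens), read by MTT assay, with a stated time of 48 h (on this read-out lower numbers stand for stronger inhibition of growth and higher numbers for weaker inhibition of growth), compound 1 gives 5770 nM. Compound 2, `Nc1ncnc2c1c(-c1cc(C3CC3)on1)nn2C1CCOCC1`, gives 1930 nM in this assay. Compound 3, `CCCCCCCn1nc(-c2cc(C3CC3)on2)c2c(N)ncnc21`, reaches only a limit of this assay, reported as > 10000 nM; that value is the limit of > 10000 nM in this assay, at which 1 of the 3 values shown sits. Of the two numbers shown, compound 1 stands highest, with compound 2 the nearer and lower one, and the gap between them lies beyond the scatter; since compound 1 and compound 2 differ in two places, that gap cannot be placed on either change alone. For the measured compounds named here, the only single-place step measured, an at least 5.1-fold higher number from compound 2 to compound 3 (0.71 log units; beyond the scatter), concerns the group on the aromatic nitrogen and not the five-membered ring, so it does not bear directly on the change now considered. Compound 4, `CC(C)n1nc(-c2ccon2)c2c(N)ncnc21`, differs from compound 1 by hydrogen in place of ethyl on an aromatic carbon. Going by the values given here, no measured step speaks to this change, so the expectation rests on compound 1 alone. Compound 4 is expected to give 12000 nM in this assay, within a range of 4000 nM to 40000 nM. That estimate means an expected step of a 2.1-fold higher number from compound 1 to compound 4 (0.32 log units; beyond the scatter), a modest weakening.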

Compound 4, concentration for 50% growth inhibition: 8940 nM
Estimate against measurement, compound 4: 1.3-fold (0.13 log units) above; the measured number falls inside the stated range.
By their numbers in this assay, from the lowest: compound 2; then compounds 1 and 4 (each within the scatter of the next). At a limit, above all of these: compound 3.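

With hydrogen in place of ethyl on an aromatic carbon of the five-membered ring, next to the ring oxygen, this assay gives a 1.5-fold higher number from compound 1 to compound 4 (0.19 log units; within the scatter). For the compounds shown here, this is the first single-place step read at this position, the earlier one having concerned the group on the aromatic nitrogen, and it shows that with isopropyl held on that nitrogen, the two carbons of the ethyl group add nothing that this read-out can separate from the scatter. Nothing measured among the compounds shown offers a reason for this outcome at this position.

On these data alone, what stays open is whether a larger or differently built group at this position, such as tert-butyl, phenyl or an amine, would give a step beyond the scatter where ethyl and hydrogen do not. Cyclopropyl also remains unplaced at this position, as compound 2 carries it together with oxan-4-yl on the aromatic nitrogen and differs from compound 1 in two places, leaving no single-place comparison with ethyl or hydrogen.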